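From trifluoromethyl to ethoxy on a shared core

The compounds below may be only part of what the source reports. "The series", "measured", "known", "first", "only" and "open" are said of these compounds alone.

Compound 1 `O=C(O)c1cnc(-c2ccccc2O)[nH]c1=O` gives > 5 mg/kg in a functional assay on the whole organism (strain Sprague-Dawley) for inhibition, with Rattus norvegicus as the target, with a stated time of 10 min (a higher number here means that more compound is needed for the effect, a lower number that less compound is needed), and this is a limit of the assay, not a number. Going by the values given here, compound 2 `O=C(O)c1cnc(-c2cccc(C(F)(F)F)c2)[nH]c1=O` gives 33 mg/kg in this assay, which is the only exact number so far, so it cannot yet be ranked against another compound. Compound 3 `CCOc1cccc(-c2ncc(C(=O)O)c(=O)[nH]2)c1` keeps the shared core but has ethoxy in place of trifluoromethyl on an aromatic carbon and is still unmeasured. Among the compounds with values here, no measured step between closely related compounds is available, so any forecast here is a rough one. The expected step of a 2.2-fold lower number from compound 2 to compound 3 (0.34 log units; beyond the scatter) is modest and points toward a lower dose, which would mean a more effective compound, and its size is close to the usual scatter. Compound 3 is estimated to give 15 mg/kg in this assay, with an expected range from 4 mg/kg to 60 mg/kg in this test.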

Compound 3, dose for 50% inhibition: 5 mg/kg
Beside the measured number, compound 3's estimate is 3.0-fold (0.48 log units) above it; low and high end bracket the measured number.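

In this assay, ethoxy in place of trifluoromethyl gives a 6.6-fold lower number from compound 2 to compound 3 (0.82 log units; beyond the scatter), so less compound is needed for the same effect. Going by these compounds alone, this is the first comparison between two exact numbers, and it shows that the dose responds to the group at this place, on an aromatic carbon, meta to a large group. None of the measurements shown speaks to why the dose changes with this swap.

A single step cannot tell whether the same trend would hold for methoxy, for a longer chain such as propoxy, or for an amine at this place. As far as these compounds go, compound 1 gives > 5 mg/kg, which is a limit of the assay and not a number, and its rank among the compounds remains open.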